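Trimming the Ester of the Weakest Compound

This account rests on a few compounds, and the source may have more. Where it says the series, first, only, none or still open, it means among the compounds named here.

In a functional assay on HT-29 cells (Homo sapiens) for cytotoxicity, read by MTT assay, with a stated time of 72 h (a higher number here means a weaker inhibitor, a lower number a stronger inhibitor), compound 2 `CCOC(=O)c1sc2cccc(C)c2c1Nc1cc(OC)c(OC)c(OC)c1` gives 3610 nM, the highest number of the three measured compounds. Compound 1 `CCOC(=O)c1sc2ccccc2c1Nc1cc(OC)c(OC)c(OC)c1` gives 1610 nM, and compound 3 `CCOC(=O)c1sc2cc(OC)ccc2c1Nc1cc(OC)c(OC)c(OC)c1` gives 10.2 nM.

The unmeasured compound 4 `COC(=O)c1sc2cccc(C)c2c1Nc1cc(OC)c(OC)c(OC)c1` differs from compound 2 by hydrogen in place of methyl on a saturated chain carbon bound to an oxygen next to a carbonyl group. This places hydrogen in place of methyl on a saturated chain carbon bound to an oxygen next to a carbonyl group, turning ethoxycarbonyl into methoxycarbonyl.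

Among the compounds with values here, no measured step bears directly on this change. Methyl in place of hydrogen on an aromatic carbon gave a 2.2-fold higher number from compound 1 to compound 2 (0.35 log units; beyond the scatter), while methoxy in place of hydrogen on an aromatic carbon gave a 160-fold lower number from compound 1 to compound 3 (2.20 log units; beyond the scatter). Both changes sit on an aromatic carbon, not on the ester chain, but their different sizes warn that one small change can matter a great deal here.

The expected result is a 1.2-fold lower number from compound 2 to compound 4 (0.08 log units; within the scatter), a step estimated to stay within the scatter, with a wide margin on either side. For compound 4 the estimated value is 3000 nM, with an expected range of 800 nM to 10000 nM.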

Compound 4, half-maximal inhibitory concentration: 1020 nM
Beside the measured number, compound 4's estimate is 2.9-fold (0.47 log units) above it, within the range that was stated.
By their numbers in this assay, from the lowest: compound 3; then compounds 4 and 1 (each within the scatter of the next); then compound 2.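

In this assay, within the data shown here, the change from ethoxycarbonyl to methoxycarbonyl gives a 3.5-fold lower number from compound 2 to compound 4 (0.55 log units; beyond the scatter) and so lies beyond the scatter, which shows that the ester chain also affects the number, a part of the molecule that no earlier step touched. This step is modest and much smaller than the change on the aromatic carbon that gave a 160-fold lower number from compound 1 to compound 3 (2.20 log units; beyond the scatter) in the same assay, so removing one carbon from the ester chain recovers only a little of what the series can reach. Nothing available explains why the shorter chain gives the lower number.

The compounds shown leave open whether the same trimming would give a similar step on the cores of compound 1 and compound 3. They also leave open how a longer chain such as propoxycarbonyl, or a carboxylic acid or an amide in place of the ester, would behave.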